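A Sulfonamide in Place of a Hydroxymethyl: Expecting Compound 4

The source may hold more compounds than are shown below. What is called first, only, known or untested is meant among the compounds shown, and "the series" means these compounds.

In a functional assay on HCT-116 cells (Homo sapiens) for antiproliferative activity, read by MTT assay, with a stated time of 72 h (a higher number here means a weaker inhibitor, a lower number a stronger inhibitor), three compounds have been measured:
compound 1 `O=C1O[C@H]([C@@H](O)Cn2cc(CNS(=O)(=O)c3ccc(F)cc3)nn2)C(OCc2ccccc2)=C1OCc1ccccc1` gives 22900 nM;
compound 2 `O=C1O[C@H]([C@@H](O)Cn2cc(CNS(=O)(=O)c3ccc(Cl)cc3)nn2)C(OCc2ccccc2)=C1OCc1ccccc1` gives 8380 nM;
compound 3 `O=C1O[C@H]([C@@H](O)Cn2cc(CCO)nn2)C(OCc2ccccc2)=C1OCc1ccccc1` gives 72700 nM.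

Compound 3 stands highest of the three, which means it is the weakest inhibitor of the set: a 3.2-fold higher number from compound 1 to compound 3 (0.50 log units; beyond the scatter) and an 8.7-fold higher number from compound 2 to compound 3 (0.94 log units; beyond the scatter). Compound 4 `O=C1O[C@H]([C@@H](O)Cn2cc(CNS(=O)(=O)c3ccc(Cl)cc3F)nn2)C(OCc2ccccc2)=C1OCc1ccccc1` differs from compound 3 in one place: ((4-chloro-2-fluorophenyl)sulfonyl)amino in place of hydroxymethyl on a saturated chain carbon bound to an aromatic carbon. The two steps above bear directly on this change, as each removed a sulfonamide of this kind and raised the number; the step of a 2.7-fold lower number from compound 1 to compound 2 (0.44 log units; beyond the scatter) shows that a chloro on that ring gave the lower number. Compound 4 carries that chloro together with a fluoro, so it is expected to fall near compound 2, estimated at 9000 nM, within 2500 nM to 30000 nM. That expectation amounts to an 8.1-fold lower number from compound 3 to compound 4 (0.91 log units; beyond the scatter) in this assay.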

Compound 4, half-maximal inhibitory concentration: 21600 nM
Compound 4: the middle estimate sits 2.4-fold (0.38 log units) below what was measured, within the range that was stated.
By their numbers in this assay, from the lowest: compound 2; then compounds 4 and 1 (each within the scatter of the next); then compound 3.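

Across this assay, the sulfonamide still gives a lower number than the hydroxymethyl when its ring carries both halogens, with a 3.4-fold lower number from compound 3 to compound 4 (0.53 log units; beyond the scatter). On the chlorinated ring, however, adding a fluoro is not neutral, giving a 2.6-fold higher number from compound 2 to compound 4 (0.41 log units; beyond the scatter), and the doubly halogenated ring ends up level with the ring carrying a single fluoro, with a 1.1-fold lower number from compound 1 to compound 4 (0.03 log units; within the scatter). No measurement here explains the cost of that added fluoro.

As far as these compounds go, whether a methoxy group on this ring would lower the number further remains open. So does whether a plain amide could replace the sulfonamide link.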